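This account rests on a few compounds, and the source may have more. Where it says the series, first, only, none or still open, it means among the compounds named here.

Measured compounds:
Compound 1 (`COc1ccc(OC(=O)c2cn(-c3ccccc3)nc2-c2cccnc2)cc1`): in a functional assay on Raji cells (Homo sapiens) for cytotoxicity, read by MTT assay, with a stated time of 48 h (on this read-out lower numbers stand for stronger inhibition and higher numbers for weaker inhibition), compound 1 is reported only as the limit > 100000 nM.
Compound 2 (`COc1ccc(OC(=O)c2cn(-c3ccccc3)nc2-c2ccncc2)cc1`): in this assay compound 2 is reported only as the limit > 100000 nM.

The two measured compounds share one core and differ only in the pyridine ring attached to it. The step that the two limits leave unreadable from compound 1 to compound 2 cannot be read, because both values sit at the limit described by the limit of > 100000 nM in this assay, at which 2 of the 2 values shown sit. Compound 2 therefore stands at no point on a scale of numbers: it is known only as a compound whose cytotoxicity toward these cells did not reach the highest concentration tested, and how far beyond that concentration its true value lies is not known.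

Compound 3 (`O=C(O)c1cn(-c2ccccc2)nc1-c1ccncc1`) has not yet been measured. It differs from compound 2 in one place: hydrogen in place of 4-methoxyphenyl on an oxygen next to a carbonyl group, so the ester of compound 2 becomes a free carboxylic acid. Among the compounds with values here, no measured step bears on this change; the only measured step is unreadable, so no direction can be taken from it. Compound 3 is expected to stay at the limit too, with an estimated value of 150000 nM in a range from 50000 nM to 500000 nM. This estimate amounts to an expected step that the limit leaves unreadable from compound 2 to compound 3 that would not be distinguishable from no change.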

Compound 3, half-maximal inhibitory concentration: > 100000 nM
Compound 3: only a limit was reported; the forecaster's own chance of this, stated with the estimate: 85%; the middle value does not contradict the limit.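

No step can be read from compound 2 to compound 3, or between any other compounds shown, because each result is a limit and not a number: the limit of > 100000 nM in this assay, at which 3 of the 3 values shown sit.

The compounds shown leave open where their true values lie, and so whether hydrogen in place of 4-methoxyphenyl changes the cytotoxicity at all.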